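A few compounds are considered here, and "the series" means these few. Any claim that something is new, unique, unknown or untested is made for them only; others in the source may bear on it.

Measured so far:
- compound 1 `Cc1ncsc1CCOC(=O)c1oc2cc(-c3ccccc3)cc(O)c2c1C`: in a functional assay on WI-38 VA13 cells (Homo sapiens) for cytotoxicity (a lower number here means that less compound is needed, a higher number that more compound is needed for the effect), compound 1 gives 0.055 ug/mL
- compound 2 `COCc1ccccc1C(=O)c1oc2cc(-c3ccccc3)cc(O)c2c1C`: in this assay compound 2 gives 0.1 ug/mL

Compound 2 holds the numerically larger of the two values, but the step of a 1.8-fold higher number from compound 1 to compound 2 (0.26 log units; within the scatter) falls within the scatter, so compound 1 and compound 2 are not separated by this assay. Among the measured compounds shown here, the exchange at the carbonyl carbon in that step is the only measured change, and it produced no movement beyond the scatter.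

Compound 3 `Cc1c(C(=O)Cc2ccccc2)oc2cc(-c3ccccc3)cc(O)c12` differs from compound 2 at the same position: benzyl in place of 2-(methoxymethyl)phenyl on a carbonyl carbon. For the measured compounds named here, both groups are carbon-only aromatics hung on the carbonyl carbon, and the one step that bears on this position was flat. No movement beyond the scatter is therefore expected in this assay.

For compound 3 a value of 0.08 ug/mL is expected, with a range from 0.03 ug/mL to 0.25 ug/mL. The step of a 1.3-fold lower number from compound 2 to compound 3 (0.10 log units; within the scatter) is the expected outcome of this change.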

Compound 3, half-maximal effective concentration: > 4 ug/mL
Compound 3: only a limit was reported; the forecaster's own chance of this, stated with the estimate: 5%; middle value at least 50-fold (1.69 log units) from the limit.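

The carbonyl carbon position is not flat in this assay: benzyl in place of 2-(methoxymethyl)phenyl gives an at least 40-fold higher number from compound 2 to compound 3 (1.60 log units; beyond the scatter), and benzyl in place of 2-(4-methyl-1,3-thiazol-5-yl)ethoxy gives an at least 72-fold higher number from compound 1 to compound 3 (1.86 log units; beyond the scatter). The leaving and entering groups in the first of these steps each hold one six-membered aromatic ring of carbon only, so that ring alone does not keep the number low. The read-out for compound 3 is a limit and not a number: the limit of > 4 ug/mL in this assay, at which 1 of the 3 values shown sits.

The compounds shown do not separate the loss of the methoxymethyl group from the exchange of a substituted phenyl for benzyl; an unsubstituted phenyl on the carbonyl carbon would bear on this. On these data alone, how an amine or a carboxylic acid at this position would read in this assay also remains open.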